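This account rests on a few compounds, and the source may have more. Where it says the series, first, only, none or still open, it means among the compounds named here.

Measured in an ADME assay on CRFK cells (Felis catus) for cytotoxicity; on this read-out lower numbers stand for higher toxicity in this test and higher numbers for lower toxicity in this test:
- compound 1 `CCN(CC)CN1C(=O)/C(=N/NC(=S)Nc2ccc(Cl)cc2)c2ccccc21`: 4000 nM
- compound 2 `CCN(CC)CN1C(=O)/C(=N/NC(=S)Nc2ccccc2)c2ccccc21`: 32300 nM

Compound 2 holds the higher number of this pair, at 32300 nM. Compound 3 `CCN(CC)CN1C(=O)/C(=N/NC(=S)Nc2ccc(C)cc2)c2ccccc21` departs from it by one change, (methyl in place of hydrogen on an aromatic carbon), with methyl in place of hydrogen on an aromatic carbon. Among the compounds with values here, only one measured step bears on this: an 8.1-fold higher number from compound 1 to compound 2 (0.91 log units; beyond the scatter), with hydrogen in place of chloro. Methyl is not chloro, so that step, read in reverse, gives only a rough guide, and a smaller move towards a lower number is expected. The expected change is a 2.5-fold lower number from compound 2 to compound 3 (0.40 log units; beyond the scatter). The estimate for compound 3 is 13000 nM, with an expected range of 4500 nM to 36000 nM.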

Compound 3, half-maximal cytotoxic concentration: 3800 nM
Estimate against measurement, compound 3: 3.4-fold (0.53 log units) above, and the stated range ends above it.
By their numbers in this assay, from the lowest: compounds 3 and 1 (each within the scatter of the next); then compound 2.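

In this assay, going from phenyl to 4-methylphenyl gives an 8.5-fold lower number from compound 2 to compound 3 (0.93 log units; beyond the scatter), so the fall seen with chloro at this position also appears with methyl. Methyl and chloro are not separated here, with a 1.1-fold lower number from compound 1 to compound 3 (0.02 log units; within the scatter) lying within the scatter. Nothing available accounts for this shared fall.

As far as these compounds go, it remains open whether a methoxy group or a fluorine atom at this position would also give such a fall. A longer chain, such as ethyl or butyl, is equally unresolved.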